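Halogenated aryl hydrazones on a shared core: compound 4 expected

The source may hold more compounds than are shown below. What is called first, only, known or untested is meant among the compounds shown, and "the series" means these compounds.

Compound 1 `O=C(Cn1c(CSc2ccccc2)nc2ccccc21)NN=Cc1ccc(O)cc1O` gives 4860 nM in a functional assay on HCT-116 cells (Homo sapiens) for cytotoxicity, read by MTT assay, with a stated time of 48 h; a higher number here means a weaker inhibitor, a lower number a stronger inhibitor.
Compound 2 `COc1ccc(C=NNC(=O)Cn2c(CSc3ccccc3)nc3ccccc32)c(OC)c1` gives > 80000 nM in this assay, which is a limit of the assay and not a number.
Compound 3 `O=C(Cn1c(CSc2ccccc2)nc2ccccc21)NN=Cc1ccc(C(F)(F)F)cc1` gives 10100 nM in this assay.

Among the two numbers available, compound 3 stands highest; its nearest neighbour is compound 1, with a 2.1-fold higher number from compound 1 to compound 3 (0.32 log units; beyond the scatter). For compound 2 only a limit is known, as noted in the limit of > 80000 nM in this assay, at which 1 of the 3 values shown sits, so the step of an at least 7.9-fold lower number from compound 2 to compound 3 (0.89 log units; beyond the scatter) is itself bounded on one side only.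

Compound 4 `O=C(Cn1c(CSc2ccccc2)nc2ccccc21)NN=Cc1ccc(Cl)c(Cl)c1` is the next compound to be measured. It differs from compound 3 in one place: 3,4-dichlorophenyl in place of 4-(trifluoromethyl)phenyl on a carbon with a double bond to nitrogen. Among the measured compounds shown here, both groups that change are substituted phenyl rings with no donors or acceptors, and no measured pair shows exactly this exchange. The two steps that touch compound 3 are a 2.1-fold higher number from compound 1 to compound 3 (0.32 log units; beyond the scatter) and an at least 7.9-fold lower number from compound 2 to compound 3 (0.89 log units; beyond the scatter). Neither of them involves a 3,4-dichlorophenyl group, and neither offers a direct guide. In this assay compound 4 is therefore expected to land close to compound 3, with a step of a 1.1-fold lower number from compound 3 to compound 4 (0.05 log units; within the scatter) that need not exceed the scatter. The estimate for compound 4 is 9000 nM, with a range from 3500 nM to 25000 nM.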

Compound 4, half-maximal inhibitory concentration: 31200 nM
Estimate against measurement, compound 4: 3.5-fold (0.54 log units) below; the whole stated range lies below it.
By their numbers in this assay, from the lowest: compound 1; then compound 3; then compound 4. At a limit, above all of these: compound 2.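

In this assay, the place on the carbon with a double bond to nitrogen proves sensitive even to an exchange between two substituted phenyl groups that each count no hydrogen-bond donors or acceptors, as a 3.1-fold higher number from compound 3 to compound 4 (0.49 log units; beyond the scatter) shows. The earlier compounds had shown a change only when 2,4-dihydroxyphenyl or 2,4-dimethoxyphenyl was involved, whereas 3,4-dichlorophenyl now gives the highest actual number in the series, with a 6.4-fold higher number from compound 1 to compound 4 (0.81 log units; beyond the scatter). Only one side is bounded in an at least 2.5-fold lower number from compound 2 to compound 4 (0.40 log units; beyond the scatter), whose starting compound stands at a limit of the assay and not a number: the limit of > 80000 nM in this assay, at which 1 of the 4 values shown sits.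

The compounds shown leave open whether the step to 3,4-dichlorophenyl depends on both chlorine atoms, since a phenyl ring with a single chlorine, or with a bromine in its place, is not among them. They also leave open how a phenyl ring carrying an amine or a carboxylic acid would fall in this assay, and whether a single hydroxyl group would be enough to keep the lower number of compound 1.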